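The compounds below may be only part of what the source reports. "The series", "measured", "known", "first", "only" and "open" are said of these compounds alone.

Measured compounds:
compound 1 `CC(C)(C)c1ccc(C(=O)N2CCC3(CC2)C(=O)N(CC(=O)N2CCC(O)CC2)CN3c2ccccc2)cc1`, 4700 nM
compound 2 `CC(C)(C)c1ccc(C(=O)N2CCC3(CC2)C(=O)N(CC(=O)N2CCCCC2CO)CN3c2ccccc2)cc1`, 11800 nM
compound 3 `CC(C)(C)c1ccc(C(=O)N2CCC3(CC2)C(=O)N(CC(=O)NCCCCO)CN3c2ccccc2)cc1`, 19200 nM

All three share one core and differ only in the group on the carbonyl carbon of the side chain. In an assay on HEK293 cells for displacement of a labelled ligand from NPC1-like intracellular cholesterol transporter 1 (Homo sapiens) (on this read-out lower numbers stand for stronger inhibition and higher numbers for weaker inhibition), compound 3 gives 19200 nM. The step of a 1.6-fold higher number from compound 2 to compound 3 (0.21 log units; within the scatter) stays within the scatter, so compound 3 and compound 2 cannot be ranked against each other, whereas a 4.1-fold higher number from compound 1 to compound 3 (0.61 log units; beyond the scatter) is beyond it.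

Compound 4 `CC(C)(C)c1ccc(C(=O)N2CCC3(CC2)C(=O)N(CC(=O)N2CCNCC2)CN3c2ccccc2)cc1` has not yet been measured. It differs from compound 3 by piperazin-1-yl in place of (4-hydroxybutyl)amino on a carbonyl carbon. The two steps that bear on this are a 4.1-fold higher number from compound 1 to compound 3 (0.61 log units; beyond the scatter) and a 1.6-fold higher number from compound 2 to compound 3 (0.21 log units; within the scatter), in which a ring replaced by an open chain went with a higher number in one case and with no change beyond the scatter in the other. Reversing that direction, toward a ring, compound 4 is expected to give a somewhat lower number, a step of about a 2.7-fold lower number from compound 3 to compound 4 (0.44 log units; beyond the scatter). For compound 4 the estimate in this assay is 7000 nM, within a range from 2500 nM to 20000 nM.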

Compound 4, half-maximal inhibitory concentration: 22000 nM
The estimate for compound 4 lay 3.1-fold (0.50 log units) below the measured number; the measured number lies above the stated range.
By their numbers in this assay, from the lowest: compound 1; then compounds 2, 3 and 4 (each within the scatter of the next).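

In this assay a ring on this carbonyl carbon does not by itself go with a lower number: the exchange of (4-hydroxybutyl)amino for piperazin-1-yl gives a 1.1-fold higher number from compound 3 to compound 4 (0.06 log units; within the scatter) and the exchange of 2-(hydroxymethyl)piperidin-1-yl for piperazin-1-yl gives a 1.9-fold higher number from compound 2 to compound 4 (0.27 log units; within the scatter) so neither step separates the compounds. Two six-membered rings can nevertheless differ here, since 4-hydroxypiperidin-1-yl and piperazin-1-yl are set apart by a 4.7-fold higher number from compound 1 to compound 4 (0.67 log units; beyond the scatter) and the ring alone therefore does not account for the lowest number of the series. Nothing measured here accounts for that difference.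

As far as these compounds go, whether the hydroxy group of compound 1 matters stays open. Plain piperidin-1-yl or morpholin-4-yl on the same carbonyl carbon would be the groups to read against 4-hydroxypiperidin-1-yl.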